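The source may hold more compounds than are shown below. What is called first, only, known or untested is meant among the compounds shown, and "the series" means these compounds.

Measured compounds in this series:

compound 1 `Nc1nc(-c2cccc(F)c2)nc2sc(Cc3ccccc3)cc12` — 123 nM
compound 2 `Nc1nc(-c2ccncc2)nc2sc(Cc3ccccc3)cc12` — 812 nM

Going by the values given here, compound 2 gives the higher of the two numbers in a functional assay on CHO-K1 cells for antagonist activity at adenosine receptor A1 (Homo sapiens), read by a beta-galactosidase reporter and cAMP accumulation, with stated times of 15 min and 6 h; a lower number here means a stronger inhibitor, a higher number a weaker inhibitor; its only neighbour is compound 1, and the step of a 6.6-fold higher number from compound 1 to compound 2 (0.82 log units; beyond the scatter) lies beyond the scatter. Compound 3 `Nc1nc(-c2cccc(Cl)n2)nc2sc(Cc3ccccc3)cc12` has not yet been measured in this assay. It differs from compound 2 in one place: 6-chloropyridin-2-yl in place of pyridin-4-yl on an aromatic carbon. Among the compounds with values here, the only measured step that bears on this position is a 6.6-fold higher number from compound 1 to compound 2 (0.82 log units; beyond the scatter), where a 3-fluorophenyl group was replaced by pyridin-4-yl and the number rose by a modest amount. Compound 3 keeps a ring nitrogen at this position but also brings back a halogen on the six-membered ring, as compound 1 has. Within the data shown here, no measured pair shows exactly this exchange, so the direction rests on that single step. The expectation is a number for compound 3 somewhat lower than that of compound 2, a step of a 2.0-fold lower number from compound 2 to compound 3 (0.31 log units; beyond the scatter) in this assay, but with wide uncertainty. The estimate for compound 3 in this assay is 400 nM, with a range from 100 nM to 1600 nM.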

Compound 3, inhibition constant: > 1000 nM
Compound 3 gave a limit, no number; the forecaster's own chance of this, stated with the estimate: 3%; middle value at least 2.5-fold (0.39 log units) away from the limit.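

In this assay compound 3 gives a limit and not a number: the limit of > 1000 nM in this assay, at which 1 of the 3 values shown sits.

The exchange of pyridin-4-yl for 6-chloropyridin-2-yl reads as an at least 1.2-fold higher number from compound 2 to compound 3 (0.09 log units; that floor lies within the scatter), so this floor alone does not place the two compounds in any order and leaves the direction of this change unsettled. The comparison with the 3-fluorophenyl compound is clearer, at an at least 8.1-fold higher number from compound 1 to compound 3 (0.91 log units; beyond the scatter): a halogen on a six-membered aromatic ring that also holds a ring nitrogen does not bring the number back to that of compound 1, and both pyridine groups shown at this position leave it higher than 3-fluorophenyl does.

How far compound 3 lies past its limit remains open, as does whether the ring nitrogen, the chlorine or the way the ring is attached accounts for the step from compound 1, since no pair shown changes only one of these features. Also open, as far as these compounds go, is how an unsubstituted phenyl ring, a 3-chlorophenyl group or a pyridine carrying an amine in place of the chlorine would read at this position in this assay.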